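The source may report more compounds than this note shows. Statements on the series, on what has been measured and on what is new or still open speak of the compounds shown alone.

Measured so far:
compound 1 `COc1cc(-c2cnn3cc(OC)c(-c4cnn(C)c4)nc23)ccn1`, with 56%
compound 2 `COc1cc(-c2cnn3cc(OC)c(C(C)(C)O)nc23)ccn1`, with 92%

In an ADME assay on microsomes from liver (Rattus norvegicus) for metabolic stability, with a stated time of 60 min, tested at 1 uM (a lower number here means that less of the compound is left, a higher number that more of the compound is left), compound 2 gives 92%, the highest of the two numbers; its nearest neighbour is compound 1, which in this assay gives 56%. Within the data shown here, the one measured step, a number 36 percentage points higher from compound 1 to compound 2 (beyond the scatter), is large and lies beyond the scatter.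

Compound 3 `COc1cnc2c(-c3ccnc(OC)c3)cnn2c1` has not yet been measured. It differs from compound 2 by hydrogen in place of 1-hydroxy-1-methylethyl on an aromatic carbon, at the place next to the ring nitrogen, ortho to a methoxy group, meta to a fused ring and para to a fused ring.

Among the measured compounds shown here, no measured step removes a group for a bare hydrogen, so the step of a number 36 percentage points higher from compound 1 to compound 2 (beyond the scatter) bears on this change only at a distance: it shows that what sits on this aromatic carbon can move the number in this assay by a large amount. Compound 1, with a different group at that carbon, sits well below compound 2. Compound 3 is therefore expected to fall below compound 2, with a step of a number 22 percentage points lower from compound 2 to compound 3 (beyond the scatter), and its estimated number in this assay is 70%, in a range from 45% to 95%.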

Compound 3, percent of the compound remaining: 10%
Compound 3: the middle estimate sits 60 percentage points above what was measured; measured number outside the range, below it.
By their numbers in this assay, from the lowest: compound 3; then compound 1; then compound 2.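

In this assay, putting hydrogen on this aromatic carbon next to the ring nitrogen gives a number 82 percentage points lower from compound 2 to compound 3 (beyond the scatter) when it replaces 1-hydroxy-1-methylethyl, and a number 46 percentage points lower from compound 1 to compound 3 (beyond the scatter) when it replaces 1-methyl-1H-pyrazol-4-yl. Among these compounds, the earlier compounds showed only that these two groups differ from each other, whereas compound 3 adds the bare position as a reference and shows that both groups go with more compound remaining than hydrogen does, with the ranking running from hydrogen through the pyrazolyl group to 1-hydroxy-1-methylethyl. Nothing available explains why the number falls so far when the group is removed.

The compounds shown leave open how much of the difference depends on the hydroxyl of 1-hydroxy-1-methylethyl, which a tert-butyl group, with its carbons and no oxygen, would help to separate. They also leave open whether a smaller group on this carbon, such as methyl or an amine, would already lift the number well above that of compound 3, or whether a longer chain carrying a hydroxyl would hold it near that of compound 2.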